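This account rests on a few compounds, and the source may have more. Where it says the series, first, only, none or still open, it means among the compounds named here.

Three compounds were measured in a functional assay on NCI-H226 cells (Homo sapiens) for inhibition, read by sulforhodamine B assay, with a stated time of 48 h; a lower number here means a stronger inhibitor of growth, a higher number a weaker inhibitor of growth:

Compound 1 `COc1cc(-c2cc(/C=C/C(=O)c3ccc(N)cc3)[nH]n2)cc(OC)c1OC`: 1710 nM
Compound 2 `COc1ccc(-c2cc(/C=C/C(=O)c3ccc(N)cc3)[nH]n2)cc1OC`: 2320 nM
Compound 3 `COc1cc(C(=O)/C=C/c2cc(-c3cc(OC)c(OC)c(OC)c3)n[nH]2)cc(OC)c1OC`: 1600 nM

Compound 1 and compound 2 differ in one place, (hydrogen in place of methoxy on an aromatic carbon), and this change gave a 1.4-fold higher number from compound 1 to compound 2 (0.13 log units; within the scatter). Compound 3 shares the trimethoxyphenyl and aminophenyl-free arrangement of its own core, but the difference between the core of compound 3 and the core of compound 1 is not broken down here; their values in this assay lie within the scatter of one another, as do the values of compound 3 and compound 2.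

Compound 4 `COc1ccc(-c2cc(/C=C/C(=O)c3cc(OC)c(OC)c(OC)c3)[nH]n2)cc1OC` is not yet measured. It differs from compound 3 by hydrogen in place of methoxy on an aromatic carbon, the same change, in the same surroundings, as that from compound 1 to compound 2. Because that earlier change gave a 1.4-fold higher number from compound 1 to compound 2 (0.13 log units; within the scatter), the step from compound 3 to compound 4 is expected to be similar, a 1.4-fold higher number from compound 3 to compound 4 (0.16 log units; within the scatter), a step that would stay within the scatter. On that basis compound 4 is estimated at 2300 nM in this assay, with a likely range from 1200 nM to 4500 nM.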

Compound 4, concentration for 50% growth inhibition: 1930 nM
For compound 4 the middle estimate is 1.2-fold (0.08 log units) above the measured one; measured number inside the range.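

In this assay, hydrogen in place of methoxy on an aromatic carbon gave a 1.2-fold higher number from compound 3 to compound 4 (0.08 log units; within the scatter). Set beside the earlier step, the same change on the other core gave a step that cannot be told apart from it: the same change on two cores in this assay, a 1.4-fold higher number (0.13 log units; within the scatter) from compound 1 to compound 2 and a 1.2-fold higher number (0.08 log units; within the scatter) from compound 3 to compound 4, 1.1-fold (0.05 log units) apart, within the scatter of two such steps. This shows that on these two cores the change left the number within the scatter, but it does not show that the change has a real effect on growth inhibition, nor that it would behave the same way on any further core in the series, and steps this small give no firm size to carry over.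

The compounds shown leave open what happens when the methoxy gives way to something other than hydrogen, such as a hydroxyl, a chlorine or a longer chain like ethoxy. They also leave open whether any such group would give a step beyond the scatter on either core.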